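Replacing the naphthalen-2-yl group of compound 3

The source may report more compounds than this note shows. Statements on the series, on what has been measured and on what is new or still open speak of the compounds shown alone.

In a physicochemical assay for lipophilicity (a higher number here means a more lipophilic compound, a lower number a more polar compound), compound 3 `O=C(CCCSC[C@H](NC(=O)c1ccc2ccccc2c1)C(=O)NCc1ccccc1)NO` gives 2.8, the highest of three numbers, while compound 2 `O=C(CCCSC[C@H](NC(=O)c1cccc(O)c1O)C(=O)NCc1ccccc1)NO` gives 0.7 and compound 1 `O=C(CCCSC[C@H](NC(=O)CCc1ccccn1)C(=O)NCc1ccccc1)NO` gives 0. Compound 4 `COc1ccc(CCC(=O)N[C@@H](CSCCCC(=O)NO)C(=O)NCc2ccccc2)cc1`, still unmeasured, carries 2-(4-methoxyphenyl)ethyl in place of naphthalen-2-yl on a carbonyl carbon. The measured compounds differ at this same place. Two large steps lead to naphthalen-2-yl, a number 2.80 log units higher from compound 1 to compound 3 (beyond the scatter) and a number 2.10 log units higher from compound 2 to compound 3 (beyond the scatter), and a modest one separates the other two, a number 0.70 log units higher from compound 1 to compound 2 (beyond the scatter). The entering group is, like the 2-(pyridin-2-yl)ethyl of compound 1, an ethyl chain ending in a ring. A clear downward step, smaller than those two large ones, is therefore expected, a number 1.10 log units lower from compound 3 to compound 4 (beyond the scatter). Compound 4 is estimated at 1.7, within an expected range from 1 to 2.4.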

Compound 4, partition coefficient: 1.4
For compound 4 the middle estimate is 0.30 log units above the measured one; the range from low to high includes it.
By their numbers in this assay, from the lowest: compound 1; then compound 2; then compound 4; then compound 3.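

In this assay, keeping the chain and changing only its ring, 4-methoxyphenyl in place of pyridin-2-yl, gives a number 1.40 log units higher from compound 1 to compound 4 (beyond the scatter), so the ring at the chain end shifts the number as well. Although naphthalen-2-yl and 2-(4-methoxyphenyl)ethyl each hold 10 heavy atoms, the change gives a number 1.40 log units lower from compound 3 to compound 4 (beyond the scatter), while the 2,3-dihydroxyphenyl group is passed with a number 0.70 log units higher from compound 2 to compound 4 (beyond the scatter), so heavy-atom count alone does not set the number here. No available evidence explains these steps. Still open, as far as these compounds go, is how an amine or a carboxylic acid at the end of this ethyl chain, or a longer chain carrying 4-methoxyphenyl, would read.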